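A Smaller Aryl Group Replaces a Larger One in Compound 2

The compounds below may be only part of what the source reports. "The series", "measured", "known", "first", "only" and "open" are said of these compounds alone.

Compound 1 `Cc1ccccc1-n1cc(-c2ccccc2)c(-c2ccc3c(c2)NC(=O)CO3)n1`: 94.8%
Compound 2 `O=C1COc2ccc(-c3[nH]c(-c4c[nH]c5ncccc45)nc3-c3ccccc3)cc2N1`: 100%
Compound 3 `O=C1COc2ccc(-c3nn(-c4ccc(F)cc4)cc3-c3ccccc3)cc2N1`: 78.2%
Compound 4 `O=C1COc2ccc(-c3[nH]c(-c4ccc(F)cc4)nc3-c3ccccc3)cc2N1`: not yet measured

In a functional assay on A549 cells (Homo sapiens) for cytotoxicity, read by colorimetric assay and MTT assay, with a stated time of 3 days, tested at 1 uM (a higher number here means a weaker effect of the compound at the concentration tested, a lower number a stronger effect), compound 2 gives 100%. Its number lies within the scatter of compound 1, which gives 94.8% in this assay, and beyond the scatter from compound 3, which gives 78.2%. Compound 4 differs from compound 2 in one place: a group of 7 heavy atoms (6 carbon, 1 fluorine; one six-membered aromatic ring of carbon only) in place of a group of 9 heavy atoms (7 carbon, 2 nitrogen; one five-membered aromatic ring with 1 hetero atom, one six-membered aromatic ring with 1 hetero atom), on an aromatic carbon. For the measured compounds named here, only one measured step bears on this change, and only loosely: the swap of 2-methylphenyl for 4-fluorophenyl on an aromatic nitrogen gave a number 16.6 percentage points lower from compound 1 to compound 3 (beyond the scatter). That step concerns a different leaving group and a different place, so it offers a pointer rather than a precedent. Going by the values given here, the one compound that carries the entering 4-fluorophenyl group, compound 3, sits at the lower end of the three numbers. On this basis compound 4 is expected to show a number somewhat lower than compound 2, with the step of a number 14 percentage points lower from compound 2 to compound 4 (beyond the scatter) estimated to be modest and possibly within the scatter. The estimated value for compound 4 in this assay is 86%, with a range from 66% to 100%.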

Compound 4, a percentage reported as activity, at one concentration (the size of the read-out at that concentration, not a potency): 97.1%
For compound 4 the middle estimate is 11.1 percentage points below the measured one; measured number inside the range.
By their numbers in this assay, from the lowest: compound 3; then compounds 1, 4 and 2 (each within the scatter of the next).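

In this assay the exchange on the aromatic carbon between two ring nitrogen atoms gives a number 2.9 percentage points lower from compound 2 to compound 4 (within the scatter) and so shows that, at this one tested concentration, 4-fluorophenyl can stand in for the larger group with no readable change. The same entering group, on an aromatic nitrogen and replacing 2-methylphenyl, gave a number 16.6 percentage points lower from compound 1 to compound 3 (beyond the scatter) and so the 4-fluorophenyl group does not bring a lower number wherever it is placed. Nothing available accounts for either outcome.

Going by these compounds, it remains open whether an amine or a carboxylic acid at this place, with no aromatic ring there at all, would leave the number just as unmoved. Also open, on these data alone, is whether the two groups would remain indistinguishable at other concentrations.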